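An aryl alkyne in place of an octyl chain

The compounds below may be only part of what the source reports. "The series", "measured", "known", "first", "only" and "open" are said of these compounds alone.

In a functional assay on L1210 cells (Mus musculus) for antiproliferative activity, read by MTT assay, with a stated time of 2 days (a lower number here means a stronger inhibitor, a higher number a weaker inhibitor), compound 2 (`CCCCCCCCC#Cc1cn(C/C=C/CN2C(=O)c3ccccc3C2=O)c(=O)[nH]c1=O`) gives only a limit, > 250000 nM, and no number. The two companions measured with a number both sit below that limit. Compound 1 (`Cc1ccc(C#Cc2cn(C/C=C\CN3C(=O)c4ccccc4C3=O)c(=O)[nH]c2=O)cc1`) gives 245000 nM in this assay. Compound 3 (`CCCCC#Cc1cn(C/C=C\CN2C(=O)c3ccccc3C2=O)c(=O)[nH]c1=O`) gives 109000 nM in this assay. The single measured step among these three, a 2.2-fold lower number from compound 1 to compound 3 (0.35 log units; beyond the scatter), puts an alkyl chain where an aryl group stood on the triple-bonded carbon, and the number falls modestly.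

Compound 4 (`CCCCc1ccc(C#Cc2cn(C/C=C/CN3C(=O)c4ccccc4C3=O)c(=O)[nH]c2=O)cc1`) differs from compound 2 by 4-butylphenyl in place of octyl on a triple-bonded carbon. This runs opposite to the measured step, since an aryl group now takes the place of a chain on the same kind of carbon; read backwards, that step, a 2.2-fold lower number from compound 1 to compound 3 (0.35 log units; beyond the scatter), points to a number that rises modestly or does not move beyond the scatter. Compound 2 already stands at the limit of > 250000 nM in this assay, at which 1 of the 3 values shown sits, so any rise would leave compound 4 beyond the reach of this assay as well. Compound 4 is therefore expected to give about 300000 nM in this assay, with a range of 120000 nM to 700000 nM, and most likely to be reported only as a limit. The step that the limit leaves unreadable from compound 2 to compound 4 is the expected change, small and no more than modest.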

Compound 4, half-maximal inhibitory concentration: 42000 nM
Compound 4: the middle estimate sits 7.1-fold (0.85 log units) above what was measured, outside the stated range (below it).
By their numbers in this assay, from the lowest: compound 4; then compound 3; then compound 1. At a limit, above all of these: compound 2.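

At the triple-bonded carbon, an aryl group in place of a chain does not have to raise the number in this assay: the new step, an at least 5.9-fold lower number from compound 2 to compound 4 (0.77 log units; beyond the scatter), runs the other way from the earlier one, a 2.2-fold lower number from compound 1 to compound 3 (0.35 log units; beyond the scatter), in which a chain replaced an aryl group. Aryl against chain alone therefore gives no fixed direction at this position, since the two pairs exchange different groups (4-methylphenyl and butyl in one, 4-butylphenyl and octyl in the other) and also carry opposite double-bond geometries in the chain on the shared core. The new step has a floor but no exact size, since compound 2 gives only a limit of the assay and no number: the limit of > 250000 nM in this assay, at which 1 of the 4 values shown sits.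

The compounds shown leave open whether the ring or the butyl on it goes with the lower number, and a plain phenyl group on the triple-bonded carbon would speak to that. Also open, from the compounds shown here alone, are the part played by the double-bond geometry and whether an amine or a carboxylic acid in place of 4-butylphenyl would keep the number this low.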